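This account rests on a few compounds, and the source may have more. Where it says the series, first, only, none or still open, it means among the compounds named here.

Working notes on the series.

Of the compounds shown here, three have been measured in an in vitro functional assay on HEK285-7 cells for antagonist activity at prostaglandin D2 receptor 2 (Homo sapiens), read by BRET and beta-arrestin recruitment; on this read-out lower numbers stand for smaller maximal responses and higher numbers for larger maximal responses. Compound 1 `Cc1nc(-c2ccc(Cl)cc2)c(CC(=O)O)s1` gives 50% in this assay. Compound 2 `CCC(c1ccccc1)c1nc(-c2ccc(Cl)cc2)c(CC(=O)O)s1` gives 50% in this assay, a number within the scatter of that of compound 1. Compound 3 `O=C(O)Cc1sc(C(c2ccc(F)cc2)c2ccc(F)cc2)nc1-c1cc(F)cc(F)c1` gives 80% in this assay, the highest of the three numbers, and its gap to both compound 1 and compound 2 is beyond the scatter. Going by the values given here, no single-point step between measured compounds is available, so no measured step size is known for any one change.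

Compound 4 `O=C(O)Cc1sc(C(c2ccc(F)cc2)c2ccc(F)cc2)nc1-c1cc(F)nc(F)c1` is the next compound to be measured. Compared with compound 3 the change is 2,6-difluoropyridin-4-yl in place of 3,5-difluorophenyl on an aromatic carbon. The rest of the structure, including the carboxymethyl group and the large group on the shared core, is unchanged. With no measured step of this kind in the series, the expected step from compound 3 to compound 4 in this assay is estimated as small, a number 5 percentage points lower from compound 3 to compound 4 (within the scatter), not clearly beyond the scatter. Compound 4 is therefore estimated to give 75% in this assay, in a range from 55% to 95%.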

Compound 4, largest response reached (reported as efficacy), in percent of the reference or control that the assay uses: 80%
For compound 4 the middle estimate is 5 percentage points below the measured one; low and high end bracket the measured number.
By their numbers in this assay, from the lowest: compounds 1 and 2 (each within the scatter of the next); then compounds 3 and 4 (each within the scatter of the next).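

In this assay, going by these compounds alone, the exchange of 3,5-difluorophenyl for 2,6-difluoropyridin-4-yl gives no change at the digits printed from compound 3 to compound 4 (within the scatter), and this is the first single-place step. At this position, on an aromatic carbon of the five-membered aromatic ring, a ring nitrogen and one hydrogen-bond acceptor therefore enter with the maximal response staying within the scatter of compound 3. No supporting measurement bears on why this exchange leaves the read-out within the scatter.

The compounds shown leave open whether a ring without fluorine, such as unsubstituted pyridin-4-yl, or a non-aromatic group such as morpholine would be tolerated at this position. Going by these compounds, it also remains open whether the same exchange would give a similar step with a different large group on the shared core.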